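The compounds below may be only part of what the source reports. "The series", "measured", "known", "first", "only" and "open" are said of these compounds alone.

Compound 1 `O=C(Nc1cccc(-c2oc3cc(-c4ccc(F)cc4)ccc3c(=O)c2O)c1)c1ccccc1F`: in a functional assay on A549 cells (Homo sapiens) for antiproliferative activity, read by CCK-8 assay, with a stated time of 72 h (on this read-out lower numbers stand for stronger inhibition and higher numbers for weaker inhibition), compound 1 gives 4410 nM.
Compound 2 `O=C(Nc1cccc(-c2oc3cc(-c4ccc(F)cc4)ccc3c(=O)c2O)c1)c1cccc(F)c1`: compound 2 gives 15400 nM.
Compound 3 `CCc1ccc(C(=O)Nc2cccc(-c3oc4cc(-c5ccc(F)cc5)ccc4c(=O)c3O)c2)cc1`: compound 3 gives 18500 nM.

Among these three, compound 1 holds the lowest number, and its two companions lie beyond the scatter from it. Compound 4 `Cc1cc(C(=O)Nc2cccc(-c3oc4cc(-c5ccc(F)cc5)ccc4c(=O)c3O)c2)ccc1F` differs from compound 1 by one change: 4-fluoro-3-methylphenyl in place of 2-fluorophenyl on a carbonyl carbon. Both measured steps away from the 2-fluorophenyl of compound 1 bear on this: a 3.5-fold higher number from compound 1 to compound 2 (0.54 log units; beyond the scatter) and a 4.2-fold higher number from compound 1 to compound 3 (0.62 log units; beyond the scatter), while the two replacements differ little from each other, a 1.2-fold higher number from compound 2 to compound 3 (0.08 log units; within the scatter). A rise of similar size is therefore expected for compound 4, an expected 3.4-fold higher number from compound 1 to compound 4 (0.53 log units; beyond the scatter). Compound 4 is estimated at 15000 nM, within 6000 nM to 40000 nM.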

Compound 4, half-maximal inhibitory concentration: 11500 nM
Estimate against measurement, compound 4: 1.3-fold (0.12 log units) above, and the stated range covers the measured number.
By their numbers in this assay, from the lowest: compound 1; then compounds 4, 2 and 3 (each within the scatter of the next).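

In this assay, the change to 4-fluoro-3-methylphenyl on the carbonyl carbon gives a 2.6-fold higher number from compound 1 to compound 4 (0.42 log units; beyond the scatter) as a third replacement, so every other group shown here on this carbonyl carbon stands above compound 1. The new group does not separate from the two earlier replacements, with a 1.6-fold lower number from compound 3 to compound 4 (0.21 log units; within the scatter) and a 1.3-fold lower number from compound 2 to compound 4 (0.13 log units; within the scatter) both staying inside the scatter, so these three form one level of activity. From the compounds shown here alone, whether a phenyl carrying an amine or a carboxylic acid, or a longer chain in place of the phenyl, would match compound 1 stays open. Nothing at hand explains why the 2-fluorophenyl stands apart.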